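Fibroblast cytotoxicity of two quinoline ether amides/sulfonamides

A few compounds are considered here, and "the series" means these few. Any claim that something is new, unique, unknown or untested is made for them only; others in the source may bear on it.

Measured so far in an ADME assay on NIH3T3 cells (Mus musculus) for cytotoxicity, read by MTT assay, with a stated time of 48 h; on this read-out higher numbers stand for weaker inhibition and lower numbers for stronger inhibition:
- compound 1 `COc1cc2c(Oc3ccc(NC(=O)c4c(C)n(C)n(-c5ccccc5)c4=O)cc3F)ccnc2cc1OCCCN1CCN(C)CC1`: 66 nM
- compound 2 `COc1cc2c(Oc3ccc(NS(=O)(=O)c4cccc(-c5cnn(C)c5)c4)cc3F)ccnc2cc1OCCCN1CCN(C)CC1`: 2480 nM

On the numbers in hand compound 2 stands highest, that is, as the weaker inhibitor of the two; compound 1 gives the lower number, and the gap between them lies beyond the scatter. Among the compounds with values here, the two compounds differ in more than one place, so no single step is drawn between them.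

Compound 3 `COc1cc2c(Oc3ccc(NS(=O)(=O)c4cccc(-c5ccsc5)c4)cc3F)ccnc2cc1OCCCN1CCN(C)CC1` follows from compound 2 by one change: thiophen-3-yl in place of 1-methyl-1H-pyrazol-4-yl on an aromatic carbon. Within the data shown here, no measured pair shows this same change, so the expected size of the step rests on nothing beyond the two values above. Within this assay the expectation for compound 3 is a step no larger than the usual scatter, if anything toward a slightly lower number, that is a 1.6-fold lower number from compound 2 to compound 3 (0.19 log units; within the scatter). Compound 3 is therefore estimated at 1600 nM, with a likely range from 500 nM to 5000 nM.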

Compound 3, half-maximal inhibitory concentration: 2350 nM
Compound 3: the middle estimate sits 1.5-fold (0.17 log units) below what was measured; the measured number falls inside the stated range.
By their numbers in this assay, from the lowest: compound 1; then compounds 3 and 2 (each within the scatter of the next).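

In this assay, within the data shown here, thiophen-3-yl in place of 1-methyl-1H-pyrazol-4-yl gives a 1.1-fold lower number from compound 2 to compound 3 (0.02 log units; within the scatter), the first single-place comparison and a step within the scatter. At this aromatic carbon, meta to a large group, the two five-membered aromatic rings cannot be told apart in this read-out, although one has 2 hetero atoms and 2 hydrogen-bond acceptors and the other has 1 of each. No measurement at hand bears on why these two groups read alike.

Open, from the compounds shown here alone, is whether this position stays as flat with a group of another kind, such as a carboxylic acid, a dimethylamino group or a longer alkyl chain. Among these compounds, also open is which part of compound 1 goes with its 66 nM, since no single-place step connects it to the other two compounds.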